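Acyl variation at the amide of the shared core

This account rests on a few compounds, and the source may have more. Where it says the series, first, only, none or still open, it means among the compounds named here.

Going by the values given here, compound 2 `O=C(Nc1c(C(O)(C(F)(F)F)C(F)(F)F)ccc2ccccc12)C1CCC1` gives 81.3 nM in a functional assay (Sus scrofa) with sulfonylurea receptors; K-ATP channels (Homo sapiens) as the target (on this read-out lower numbers stand for an effect already at smaller amounts and higher numbers for an effect only at larger amounts of compound), the lowest of the two numbers so far; compound 1 `CCCC(=O)Nc1c(C(O)(C(F)(F)F)C(F)(F)F)ccc2ccccc12` gives 708 nM. Among the compounds with values here, the single measured step, an 8.7-fold lower number from compound 1 to compound 2 (0.94 log units; beyond the scatter), describes cyclobutyl in place of propyl. Compound 3 `COCC(=O)Nc1c(C(O)(C(F)(F)F)C(F)(F)F)ccc2ccccc12` carries methoxymethyl in place of cyclobutyl on a carbonyl carbon. Within the data shown here, no measured step covers this exchange directly; the only step shows the ring-bearing acyl group giving the lower number than a group without a ring, and methoxymethyl again has no ring, so for compound 3 a shift upward is expected, a 6.2-fold higher number from compound 2 to compound 3 (0.79 log units; beyond the scatter). For compound 3 the estimate is 500 nM, within 150 nM to 1600 nM.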

Compound 3, half-maximal effective concentration: 204 nM
The estimate for compound 3 lay 2.5-fold (0.39 log units) above the measured number; measured number inside the range.
By their numbers in this assay, from the lowest: compound 2; then compound 3; then compound 1.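

At this acyl position, a ring is not needed for a number below that of compound 1: methoxy in place of ethyl on a saturated chain carbon bound to a carbonyl carbon goes with a 3.5-fold lower number from compound 1 to compound 3 (0.54 log units; beyond the scatter) in this assay. Methoxymethyl does not match cyclobutyl, however, with a 2.5-fold higher number from compound 2 to compound 3 (0.40 log units; beyond the scatter). No measurement at hand accounts for either step. Still open, on these data alone, is whether cyclopentyl or phenyl on the carbonyl carbon would go lower than cyclobutyl, and whether a dimethylamino group in place of the methoxy would preserve the step seen with compound 3.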